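A few compounds are considered here, and "the series" means these few. Any claim that something is new, unique, unknown or untested is made for them only; others in the source may bear on it.

Compound 1 `CC(=O)c1cc(-c2ccccc2)cc2cc(-c3ccccc3)[nH]c12` and compound 2 `CC(=O)c1cc(-c2ccccc2)cc2cc(-c3ccc(F)cc3)[nH]c12` share a core and differ by fluoro in place of hydrogen on an aromatic carbon; in a functional assay on HeLa cells (Homo sapiens) for cytotoxicity, read by MTT assay, with a stated time of 2 days, tested at 1 uM (a lower number here means a stronger effect, a higher number a weaker effect of the compound at the concentration tested), compound 1 gives 65.8%, while compound 2 gives 85.1%, so that a number 19.3 percentage points higher from compound 1 to compound 2 (beyond the scatter). Compound 3 `CC(=O)c1cc(/C=C/c2ccccc2)cc2cc(-c3ccc(F)cc3)[nH]c12` carries the same fluoro as compound 2 but differs from it by 2-phenylethenyl in place of phenyl, and in this assay compound 3 gives 60.5%, which is a number 24.6 percentage points lower from compound 2 to compound 3 (beyond the scatter). The difference between the core of compound 1 and the core of compound 3 is not broken down here. Compound 4 `CC(=O)c1cc(/C=C/c2ccc(F)cc2)cc2cc(-c3ccc(F)cc3)[nH]c12` differs from compound 3 by fluoro in place of hydrogen on an aromatic carbon, the same change that turned compound 1 into compound 2. For compound 4 the expected step is a number 14.5 percentage points higher from compound 3 to compound 4 (beyond the scatter), resting on the earlier step because a number 19.3 percentage points higher from compound 1 to compound 2 (beyond the scatter). Compound 4 is therefore estimated at 75%, from 60% to 90%.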

Compound 4, a percentage reported as activity, at one concentration (the size of the read-out at that concentration, not a potency): 53.7%
Compound 4: the middle estimate sits 21.3 percentage points above what was measured, outside the stated range (below it).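

Fluoro in place of hydrogen did not carry over from one core to the other in this assay: the same change on two cores in this assay, a number 19.3 percentage points higher (beyond the scatter) from compound 1 to compound 2 and a number 6.8 percentage points lower (within the scatter) from compound 3 to compound 4, 26.1 percentage points apart, beyond the scatter of two such steps. Within the data shown here, on the stilbene-free reading of the series, the one clear shift around compound 4 is a number 31.4 percentage points lower from compound 2 to compound 4 (beyond the scatter), which goes with 2-(4-fluorophenyl)ethenyl in place of phenyl, whereas the fluoro step alone is a number 6.8 percentage points lower from compound 3 to compound 4 (within the scatter). Among these compounds, this shows that the step seen on the core of compound 1 cannot simply be added on the core of compound 3, but with only two pairs it does not show why the steps differ or how they would fall on a further core. The compounds shown leave open how chloro, methoxy or an amine would behave in place of that fluoro. They also leave open whether a longer chain in place of 2-phenylethenyl would keep the number of compound 4 at 53.7%.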